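The source may hold more compounds than are shown below. What is called first, only, known or untested is meant among the compounds shown, and "the series" means these compounds.

Compound 2 `Cc1ncc([N+](=O)[O-])n1CCOc1ccc(F)cc1` gives 85.8 ug/mL in a functional assay on MCF7 cells (Homo sapiens) for cytotoxicity, read by MTT assay, with a stated time of 24 h (on this read-out higher numbers stand for weaker inhibition and lower numbers for stronger inhibition), the smallest of the three numbers, though its neighbours lie within the scatter: compound 1 `Cc1ncc([N+](=O)[O-])n1CCOc1ccccc1` gives 106 ug/mL and compound 3 `Cc1ncc([N+](=O)[O-])n1CCOc1ccc(F)c(Cl)c1` gives 110 ug/mL. The two measured steps on this ring were both small: a 1.2-fold lower number from compound 1 to compound 2 (0.09 log units; within the scatter) and a 1.3-fold higher number from compound 2 to compound 3 (0.11 log units; within the scatter). Compound 4 `Cc1ncc([N+](=O)[O-])n1CCOc1ccc([N+](=O)[O-])cc1` differs from compound 2 by nitro in place of fluoro on an aromatic carbon. Among the measured compounds shown here, no measured step exchanges fluoro for nitro, so only the general flatness of this series guides expectation. Compound 4 is therefore expected to show a 1.1-fold higher number from compound 2 to compound 4 (0.04 log units; within the scatter), no change beyond the scatter. The estimate for compound 4 in this assay is 95 ug/mL, with a range from 55 ug/mL to 165 ug/mL.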

Compound 4, half-maximal inhibitory concentration: 127 ug/mL
The estimate for compound 4 lay 1.3-fold (0.13 log units) below the measured number, within the range that was stated.
By their numbers in this assay, from the lowest: compounds 2, 1, 3 and 4 (each within the scatter of the next).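

In this assay, the step to nitro, a group of three heavy atoms with two hydrogen-bond acceptors, on this aromatic carbon para to a large group is a 1.5-fold higher number from compound 2 to compound 4 (0.17 log units; within the scatter). Set against hydrogen, the same group gives a 1.2-fold higher number from compound 1 to compound 4 (0.08 log units; within the scatter), so this larger change also leaves the number within the scatter. No available evidence explains this flat result. As far as these compounds go, whether an amine or a carboxylic acid at this place would move the number beyond the scatter remains open.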